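Benzyl in place of 2-chlorophenyl: working notes

A few compounds are considered here, and "the series" means these few. Any claim that something is new, unique, unknown or untested is made for them only; others in the source may bear on it.

Measured in a functional assay on U-373MG ATCC cells (Homo sapiens) for inhibition, read by MTT assay, with a stated time of 72 h (a lower number here means a stronger inhibitor, a higher number a weaker inhibitor), as follows:
- compound 1 `CC1(C)CC(NC(=O)NCc2ccccc2)c2cc(Br)ccc2O1` gives 27000 nM
- compound 2 `CC1(C)CC(NC(=O)Nc2ccccc2)c2cc(Cl)ccc2O1` gives 68000 nM
- compound 3 `CC1(C)CC(NC(=O)Nc2ccccc2Cl)c2cc(Cl)ccc2O1` gives 17000 nM

Compound 3 at 17000 nM lies within the scatter of compound 1 and clear of compound 2 at 68000 nM in this assay. Compound 4 `CC1(C)CC(NC(=O)NCc2ccccc2)c2cc(Cl)ccc2O1` is not yet measured. Its difference from compound 3 is benzyl in place of 2-chlorophenyl on an amide-type nitrogen. Within the data shown here, one measured step bears on this: a 4.0-fold lower number from compound 2 to compound 3 (0.60 log units; beyond the scatter) came with chloro in place of hydrogen on an aromatic carbon, and the benzyl that enters carries no chlorine. Compound 1 already has benzyl in this place and reads 27000 nM in this assay, so a large move is not expected. A small rise in the number is expected, not clearly beyond the scatter. The expected step is a 1.8-fold higher number from compound 3 to compound 4 (0.25 log units; within the scatter) in this assay. For compound 4 the estimate is 30000 nM with an expected range from 14000 nM to 65000 nM.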

Compound 4, half-maximal inhibitory concentration: 66000 nM
Compound 4: the middle estimate sits 2.2-fold (0.34 log units) below what was measured, outside the stated range (above it).
By their numbers in this assay, from the lowest: compounds 3 and 1 (each within the scatter of the next); then compounds 4 and 2 (each within the scatter of the next).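

In this assay the longer benzyl offers no advantage over phenyl on the amide-type nitrogen, with a 1.0-fold lower number from compound 2 to compound 4 (0.01 log units; within the scatter) in the chloro series. The lower number of compound 3 therefore stays tied to its 2-chlorophenyl among these compounds, and benzyl does not retain it: the change gives a 3.9-fold higher number from compound 3 to compound 4 (0.59 log units; beyond the scatter) and nearly matches the size of a 4.0-fold lower number from compound 2 to compound 3 (0.60 log units; beyond the scatter) in the opposite direction. The halogen on the core also matters with benzyl in place, as a 2.4-fold higher number from compound 1 to compound 4 (0.39 log units; beyond the scatter) comes with chloro in place of bromo on an aromatic carbon, so the value of compound 1 does not carry over to the chloro series.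

From the compounds shown here alone, it remains open whether chloro on the benzyl group would restore the lower number, and whether methoxy or an amine could replace the chloro of 2-chlorophenyl and keep it. No supporting data bear on these shifts.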